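Dropping a chloro group from a dichloro purine core

The compounds below may be only part of what the source reports. "The series", "measured", "known", "first", "only" and "open" are said of these compounds alone.

Compound 1 `Nc1nc(Cl)c2ncn(Cc3ccccc3CCl)c2n1` gives 39800 nM in a functional assay on OVCAR-5 cells (Homo sapiens) for cytotoxicity, read by sulforhodamine B assay, with a stated time of 48 h; on this read-out lower numbers stand for stronger inhibition of growth and higher numbers for weaker inhibition of growth; compound 2 `ClCc1ccccc1Cn1cnc2nc(Cl)nc(Cl)c21` gives 5750 nM.

Compound 2 gives the lower of the two numbers in this assay, and its gap to compound 1 lies beyond the usual scatter. Compound 3 `ClCc1ccccc1Cn1cnc2ncnc(Cl)c21` has not yet been measured. It differs from compound 2 by one change: hydrogen in place of chloro on an aromatic carbon. Among the measured compounds shown here, no measured pair shows this change, so its effect is unknown here. A small rise in the number is expected for compound 3, as a 1.6-fold higher number from compound 2 to compound 3 (0.19 log units; within the scatter), possibly within the scatter. The estimate for compound 3 in this assay is 9000 nM, with a range from 3000 nM to 27000 nM.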

Compound 3, concentration for total growth inhibition: 7240 nM
Compound 3: the middle estimate sits 1.2-fold (0.09 log units) above what was measured; measured number inside the range.
By their numbers in this assay, from the lowest: compounds 2 and 3 (each within the scatter of the next); then compound 1.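

With hydrogen in place of the chloro group on the aromatic carbon between two ring nitrogen atoms, this assay gives a 1.3-fold higher number from compound 2 to compound 3 (0.10 log units; within the scatter), so this pair cannot be told apart. For these two compounds, then, the chloro group at this position is not needed for the growth inhibition seen here. Nothing on hand explains this result.

On these data alone, whether a methoxy or methyl group on this carbon would give a different number remains open. So does the effect of hydrogen in place of the other chloro group.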